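This account rests on a few compounds, and the source may have more. Where it says the series, first, only, none or still open, it means among the compounds named here.

In a functional assay on MCF7 cells (Homo sapiens) for cytotoxicity, read by sulforhodamine B assay, with a stated time of 48 h (a higher number here means a weaker inhibitor of growth, a lower number a stronger inhibitor of growth), the three measured compounds stand as follows:

compound 1 `NC(=S)N/N=C1/C(=O)N(CN2CCN(c3ccnc4cc(Cl)ccc34)CC2)c2cccc(Cl)c21` gives 57500 nM
compound 2 `NC(=S)N/N=C1/C(=O)N(CN2CCN(c3ccnc4cc(Cl)ccc34)CC2)c2cccc(Br)c21` gives 46600 nM
compound 3 `NC(=S)N/N=C1/C(=O)N(CN2CCN(c3ccnc4cc(Cl)ccc34)CC2)c2ccccc21` gives 23000 nM

Compound 1 has the highest number of the three. Its gap to compound 2 is small, a 1.2-fold lower number from compound 1 to compound 2 (0.09 log units; within the scatter), so the two cannot be told apart, whereas a 2.5-fold lower number from compound 1 to compound 3 (0.40 log units; beyond the scatter) and a 2.0-fold lower number from compound 2 to compound 3 (0.31 log units; beyond the scatter) are modest steps beyond the scatter.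

Compound 4 `NC(=S)N/N=C1/C(=O)N(CN2CCN(c3ccnc4cc(C(F)(F)F)ccc34)CC2)c2cccc(Cl)c21` differs from compound 1 in one place: trifluoromethyl in place of chloro on an aromatic carbon. This change sits on the fused two-ring system, a different part of the shared core from the one altered in the measured steps, which all concern the halogen on the other ring. Among the measured compounds shown here, none of the measured steps therefore bears directly on it, and the only guide is that the one swap of one halogen for another, a 1.2-fold lower number from compound 1 to compound 2 (0.09 log units; within the scatter), stayed within the scatter. The expectation for this assay is accordingly no step beyond the scatter, a 1.0-fold lower number from compound 1 to compound 4 (0.02 log units; within the scatter), and compound 4 is estimated at 55000 nM, with a range from 25000 nM to 130000 nM.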

Compound 4, concentration for 50% growth inhibition: 21600 nM
Compound 4: the middle estimate sits 2.5-fold (0.41 log units) above what was measured; the measured number lies below the stated range.
By their numbers in this assay, from the lowest: compounds 4 and 3 (each within the scatter of the next); then compounds 2 and 1 (each within the scatter of the next).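

Replacing chloro with trifluoromethyl on the six-membered aromatic ring of carbon only, part of the fused system of two rings, gives a 2.7-fold lower number from compound 1 to compound 4 (0.43 log units; beyond the scatter) in this assay. Among the compounds shown here, the earlier steps all changed the halogen on the other part of the shared core, so this is the first sign that a change at this position can also move the number beyond the scatter, here towards stronger growth inhibition. Nothing measured here accounts for the size or direction of this step.

The compounds shown leave open whether a smaller or larger change at this position, such as hydrogen, an amine or a methoxy group, would move the number further or reverse it. They also leave open whether trifluoromethyl here would give a similar step with bromo or hydrogen in place of chloro on the other ring.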